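Adding fluorines to the phenoxy group of compound 3

A few compounds are considered here, and "the series" means these few. Any claim that something is new, unique, unknown or untested is made for them only; others in the source may bear on it.

Values measured in a functional assay on Jurkat cells (Homo sapiens) (on this read-out higher numbers stand for weaker inhibition and lower numbers for stronger inhibition), so far:
- compound 1 `CC(C)[C@H](NC(=O)COc1cccc2ccccc12)C(=O)N[C@@H](CC(=O)O)C(=O)COc1ccccc1` gives 14000 nM
- compound 2 `CC(C)[C@H](NC(=O)COc1cccc2ccccc12)C(=O)N[C@@H](CC(=O)O)C(=O)COc1cc(F)c(F)cc1F` gives 39300 nM
- compound 3 `CC(C)[C@H](NC(=O)COc1cccc2ccccc12)C(=O)N[C@@H](CC(=O)O)C(=O)COc1c(F)cc(F)cc1F` gives 6840 nM

Compound 3 has the lowest number of the three (6840 nM), and both gaps to it lie beyond the scatter. The next compound, compound 4 `CC(C)[C@H](NC(=O)COc1cccc2ccccc12)C(=O)N[C@@H](CC(=O)O)C(=O)COc1c(F)c(F)c(F)c(F)c1F`, keeps the shared core and puts 2,3,4,5,6-pentafluorophenyl in place of 2,4,6-trifluorophenyl on an oxygen on a saturated carbon.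

All three measured steps changed this same group, and all were modest. The first is a 2.8-fold higher number from compound 1 to compound 2 (0.45 log units; beyond the scatter) and ran upward. The second is a 2.0-fold lower number from compound 1 to compound 3 (0.31 log units; beyond the scatter) and ran downward. The third, between the two trifluorophenyl compounds, is a 5.7-fold lower number from compound 2 to compound 3 (0.76 log units; beyond the scatter) and is the largest. Adding fluorines to the phenyl group therefore moved the number both ways, and these compounds give no direction for further fluorines. A step no larger than these is expected in this assay, most likely none beyond the scatter, with a slight rise as the estimate. The estimated step is a 1.2-fold higher number from compound 3 to compound 4 (0.07 log units; within the scatter) and no more. Compound 4 is expected at 8000 nM in an estimated range of 2500 nM to 26000 nM in this read-out.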

Compound 4, half-maximal inhibitory concentration: 3050 nM
Compound 4: the middle estimate sits 2.6-fold (0.42 log units) above what was measured; low and high end bracket the measured number.
By their numbers in this assay, from the lowest: compound 4; then compound 3; then compound 1; then compound 2.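

In this assay, within the data shown here, compound 4 is the strongest inhibitor of the four, with a 2.2-fold lower number from compound 3 to compound 4 (0.35 log units; beyond the scatter), a 4.6-fold lower number from compound 1 to compound 4 (0.66 log units; beyond the scatter) and a 13-fold lower number from compound 2 to compound 4 (1.11 log units; beyond the scatter), the last being the only large step among the new ones. The group on the oxygen therefore accepts 2,3,4,5,6-pentafluorophenyl and gains from it, and the order phenyl, 2,4,6-trifluorophenyl, 2,3,4,5,6-pentafluorophenyl now runs steadily downward, though compound 2 goes against any reading in which more fluorines simply give a lower number, since it stands above compound 1 despite carrying the same count of fluorines as compound 3. No measurement is at hand that accounts for this order or for the gap between the two trifluorophenyl compounds.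

The compounds shown leave open whether a phenyl group bearing chlorine or a methoxy group on the same oxygen would continue this downward run, or whether a saturated cyclohexyl ring there would retain any of it. They also leave open whether the gain from 2,3,4,5,6-pentafluorophenyl would hold if the carboxylic acid of the shared core gave way to a primary amide.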